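Anilino variation on the shared core, growth inhibition

A few compounds are considered here, and "the series" means these few. Any claim that something is new, unique, unknown or untested is made for them only; others in the source may bear on it.

Measured so far:
compound 1 `CN1CCN(CCCOc2cccc3nc(Nc4ccc(Cl)c(C(F)(F)F)c4)ccc23)CC1` gives 2000 nM in a functional assay on Hs-578T cells (Homo sapiens) for inhibition, read by sulforhodamine B assay, with a stated time of 48 h; a lower number here means a stronger inhibitor of growth, a higher number a weaker inhibitor of growth
compound 2 `CC(C)c1ccc(Nc2ccc3c(OCCCN4CCN(C)CC4)cccc3n2)cc1` gives 16900 nM in this assay
compound 3 `CN1CCN(CCCOc2cccc3nc(Nc4ccc(F)c(F)c4)ccc23)CC1` gives 4730 nM in this assay

Compound 3 stands second highest of the three numbers. The two steps that place it are a 2.4-fold higher number from compound 1 to compound 3 (0.37 log units; beyond the scatter) and a 3.6-fold lower number from compound 2 to compound 3 (0.55 log units; beyond the scatter); the third measured step, an 8.5-fold higher number from compound 1 to compound 2 (0.93 log units; beyond the scatter), spans the whole set. All three steps change the same aryl group on the same nitrogen of the shared core, so all three bear on the next change.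

Compound 4 `CN1CCN(CCCOc2cccc3nc(Nc4cc(Cl)cc(Cl)c4)ccc23)CC1` is reached from compound 3 by 3,5-dichlorophenyl in place of 3,4-difluorophenyl on a nitrogen on an aromatic ring. The measured steps for this position have all been modest, with the halogenated aryl groups of compound 1 and compound 3 giving the lower numbers and the 4-isopropylphenyl of compound 2 the highest. Compound 4 keeps a halogenated aryl group, so a step within the modest range is expected, probably toward a lower number, as a 1.6-fold lower number from compound 3 to compound 4 (0.20 log units; within the scatter). For compound 4 in this assay the estimate is 3000 nM, with a range from 1000 nM to 9000 nM.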

Compound 4, concentration for 50% growth inhibition: 2500 nM
For compound 4 the middle estimate is 1.2-fold (0.08 log units) above the measured one; low and high end bracket the measured number.
By their numbers in this assay, from the lowest: compounds 1, 4 and 3 (each within the scatter of the next, the first and the last beyond it); then compound 2.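

On a nitrogen on an aromatic ring, exchanging one dihalogenated phenyl for another changes little in this assay: 3,5-dichlorophenyl gives a 1.9-fold lower number from compound 3 to compound 4 (0.28 log units; within the scatter) and, against 4-chloro-3-(trifluoromethyl)phenyl, a 1.3-fold higher number from compound 1 to compound 4 (0.10 log units; within the scatter), even though the step between compound 1 and compound 3 lies beyond the scatter. The separation from the only aryl group without halogen also holds for this third halogenated group, with a 6.8-fold lower number from compound 2 to compound 4 (0.83 log units; beyond the scatter), so all the halogenated aryl groups shown give lower numbers than compound 2. No measurement at hand explains these steps.

Open, on these data alone, is where a phenyl carrying a single chlorine, a methoxy group or a carboxylic acid would fall in this assay relative to these four compounds. Also open, as far as these compounds go, is whether these steps would persist with a longer chain joining the shared core to its terminal amine.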